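Isopropyl in place of hydrogen on the acid-bearing carbon

This account rests on a few compounds, and the source may have more. Where it says the series, first, only, none or still open, it means among the compounds named here.

Measured so far in an ADME assay on KB cells (Homo sapiens) for cytotoxicity, with a stated time of 48 h; a lower number here means a stronger inhibitor, a higher number a weaker inhibitor:
compound 1 `CC1=CCC[C@H]2[C@](C)(CC3=C(O)C(=O)C=C(N[C@@H](CO)C(=O)O)C3=O)[C@@H](C)CC[C@]12C` gives 7.6 ug/mL
compound 2 `CC1=CCC[C@](C)(CC/C(C)=C/CC2=C(O)C(=O)C=C(NCC(=O)O)C2=O)[C@@H]1C` gives 5.4 ug/mL
compound 3 `C=C1[C@H](C)CCC[C@]1(C)CC/C(C)=C/CC1=C(O)C(=O)C=C(N[C@H](C(=O)O)[C@@H](C)O)C1=O` gives > 10 ug/mL

Compound 3 sits at a limit of this assay, (the limit of > 10 ug/mL in this assay, at which 1 of the 3 values shown sits), and no number is known for it. Of the two numbers that are known, compound 2 has the lower one, yet compound 2 and compound 1 lie within the usual scatter of each other, so nothing separates them. Compound 1 and compound 3 differ from compound 2 in more than one place, so none of these pairs forms a single step.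

Compound 4 `CC1=CCC[C@](C)(CC/C(C)=C/CC2=C(O)C(=O)C=C(N[C@@H](C(=O)O)C(C)C)C2=O)[C@@H]1C` has not yet been measured in this assay. It differs from compound 2 in one place: isopropyl in place of hydrogen on a saturated chain carbon bound to an amine nitrogen and a carbonyl carbon. The isopropyl enters where compound 2 carries only hydrogen, on the carbon that links the amine nitrogen to the carboxylic acid.

Among the compounds with values here, with no single step between measured compounds to lean on, the expectation for compound 4 rests on compound 2 alone, whose value of 5.4 ug/mL is the starting point. The step from compound 2 to compound 4 is expected to be small, a 1.3-fold higher number from compound 2 to compound 4 (0.11 log units; within the scatter), and not clearly beyond the scatter in either direction. Compound 4 is therefore expected to give about 7 ug/mL in this assay, between 3.5 ug/mL and 14 ug/mL.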

Compound 4, half-maximal inhibitory concentration: > 10 ug/mL
Compound 4 gave a limit, no number; the forecaster's own chance of this, stated with the estimate: 25%; middle value at least 1.4-fold (0.15 log units) away from the limit.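

In this assay compound 4 gives > 10 ug/mL, which is a limit of the assay and not a number. Within the data shown here, this gives the first single change that can be read at this position: isopropyl in place of hydrogen on a saturated chain carbon bound to an amine nitrogen and a carbonyl carbon reads as an at least 1.8-fold higher number from compound 2 to compound 4 (0.26 log units; that floor lies within the scatter), so the change points towards a weaker inhibitor, but the floor of the step does not by itself separate the two compounds. Compound 4 now stands at the same limit as compound 3, so it gives no number to set against the other compounds: the limit of > 10 ug/mL in this assay, at which 2 of the 4 values shown sit.

The compounds shown leave open how large the step really is, since only its floor is known, and whether it belongs to isopropyl in particular or to any group on this carbon in place of hydrogen. Whether a methyl or a benzyl on the same carbon, with the rest of compound 2 unchanged, would give a number in this assay or reach the same limit cannot be told from them.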